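Phenyl for Propylamino on a Carbonyl Carbon

The source may report more compounds than this note shows. Statements on the series, on what has been measured and on what is new or still open speak of the compounds shown alone.

In a physicochemical assay for solubility, at pH 7 (on this read-out higher numbers stand for higher solubility and lower numbers for lower solubility), compound 3 `CCCNC(=O)Nc1n[nH]c2c1CN(C(=O)C1CCN(C)CC1)C2(C)C` gives > 225000 nM, which is a limit and not a number. Compound 1 `CN1CCC(C(=O)N2Cc3c(NC(=O)c4ccco4)n[nH]c3C2(C)C)CC1` gives > 225000 nM, also a limit. Compound 2 `CN1CCC(C(=O)N2Cc3c(NC(=O)c4ccncc4)n[nH]c3C2(C)C)CC1` gives > 225000 nM, again a limit. All three therefore stand at the limit of > 225000 nM in this assay, at which 3 of the 3 values shown sit.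

Compound 4 `CN1CCC(C(=O)N2Cc3c(NC(=O)c4ccccc4)n[nH]c3C2(C)C)CC1` carries phenyl in place of propylamino on a carbonyl carbon.

The measured swaps at that same place are a step that the two limits leave unreadable from compound 1 to compound 3, a step that the two limits leave unreadable from compound 2 to compound 3 and a step that the two limits leave unreadable from compound 1 to compound 2. None of them gives a size or a direction, so only a weak expectation is possible: no change beyond the usual scatter. The expected outcome is a number no higher from compound 3 to compound 4 (the limit leaves the size open). For compound 4 the estimate is 225000 nM, with an expected range of 110000 nM to 450000 nM.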

Compound 4, solubility: > 225000 nM
Compound 4 was reported as a limit; the forecaster's own chance of this, stated with the estimate: 70%; the middle value sits exactly at the limit.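

In this assay compound 4 gives > 225000 nM, which is a limit and not a number. Within the data shown here, no step to compound 4 from compound 1, compound 2 or compound 3 can be read. From the compounds shown here alone, how far these four compounds differ in solubility stays open: the limit of > 225000 nM in this assay, at which 4 of the 4 values shown sit.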